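Furan-3-yl gives way to cyclopropyl

A few compounds are considered here, and "the series" means these few. Any claim that something is new, unique, unknown or untested is made for them only; others in the source may bear on it.

Measured so far in a functional assay on the whole organism with Mus musculus as the target (a lower number here means that less compound is needed, a higher number that more compound is needed for the effect), are these compounds
Compound 1 `C[C@@H](NCc1ccc(OCc2ccccn2)cc1)C(N)=O` gives 172 mg/kg
Compound 2 `C[C@@H](NCc1ccc(OCc2cccs2)cc1)C(N)=O` gives 61.6 mg/kg
Compound 3 `C[C@@H](NCc1ccc(OCc2ccoc2)cc1)C(N)=O` gives 152 mg/kg

The three compounds share one core and differ only in the ring on a saturated chain carbon bound to an oxygen on an aromatic ring. Compound 3 lies level with compound 1 and clearly above compound 2. The data show a 1.1-fold lower number from compound 1 to compound 3 (0.05 log units; within the scatter) and also a 2.5-fold higher number from compound 2 to compound 3 (0.39 log units; beyond the scatter) in this series.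

Compound 4 `C[C@@H](NCc1ccc(OCC2CC2)cc1)C(N)=O` has not been measured yet. The structural change is cyclopropyl in place of furan-3-yl on a saturated chain carbon bound to an oxygen on an aromatic ring in this last step. Put simply, it is cyclopropyl in place of furan-3-yl at that same place.

The measured steps bearing on this change each swap one ring for another there. The largest of them is a 2.8-fold lower number from compound 1 to compound 2 (0.45 log units; beyond the scatter) and it counts as modest. For the measured compounds named here, no measured compound carries a non-aromatic ring at this place, so these steps are only a loose guide, and they favour no direction.

The expected outcome is a 1.3-fold lower number from compound 3 to compound 4 (0.10 log units; within the scatter) in this assay and thus no clear shift beyond the scatter. Compound 4 is estimated at 120 mg/kg with an expected range from 50 mg/kg to 290 mg/kg as the likely span.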

Compound 4, dose for half-maximal effect: 124 mg/kg
For compound 4 the middle estimate is 1.0-fold (0.01 log units) below the measured one; low and high end bracket the measured number.
By their numbers in this assay, from the lowest: compounds 2, 4, 3 and 1 (each within the scatter of the next, the first and the last beyond it).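

For the compounds shown here, compound 4 is the first compound here with a non-aromatic ring at this place, and in this assay cyclopropyl, with fewer heavy atoms than furan-3-yl and no hydrogen-bond acceptor, leaves the number within the scatter of the furan compound, with a 1.2-fold lower number from compound 3 to compound 4 (0.09 log units; within the scatter). The same holds against the pyridine compound, with a 1.4-fold lower number from compound 1 to compound 4 (0.14 log units; within the scatter), and against the thiophene compound, with a 2.0-fold higher number from compound 2 to compound 4 (0.30 log units; within the scatter), although compound 1 and compound 3 each lie beyond the scatter of compound 2. Among these four compounds, then, an aromatic ring on the saturated chain carbon is not required for a number in this range, and compound 4 cannot be separated from any of the other three.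

Nothing available here accounts for the way the number responds to these ring changes. The compounds shown also leave open whether a ring matters at all at this place, since a plain ethyl or a longer carbon chain could be set against cyclopropyl, and whether a larger saturated ring such as cyclohexyl, or an amine or a carboxylic acid on that chain, would move the number beyond the scatter.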